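The source may hold more compounds than are shown below. What is called first, only, known or untested is meant among the compounds shown, and "the series" means these compounds.

Series notes. Within the data shown here, compound 3 `Nc1nc(SCc2ccc(F)cc2)c2ncn([C@@H]3O[C@H](CO)[C@@H](O)[C@H]3O)c2n1` gives 1150 nM in an assay on isolated protein for binding affinity to Equilibrative nucleoside transporter 1 (Homo sapiens) (on this read-out lower numbers stand for stronger inhibition and higher numbers for weaker inhibition), the lowest of the three numbers so far. Compound 1 `Nc1nc(SCc2cccc(Br)c2)c2ncn([C@@H]3O[C@H](CO)[C@@H](O)[C@H]3O)c2n1` gives 2880 nM and compound 2 `CCCCSc1nc(N)nc2c1ncn2[C@@H]1O[C@H](CO)[C@@H](O)[C@H]1O` gives 12000 nM; the steps are a 2.5-fold lower number from compound 1 to compound 3 (0.40 log units; beyond the scatter) and a 10-fold lower number from compound 2 to compound 3 (1.02 log units; beyond the scatter), both beyond the scatter. Compound 4 `Nc1nc(SI)c2ncn([C@@H]3O[C@H](CO)[C@@H](O)[C@H]3O)c2n1` differs from compound 3 by iodo in place of 4-fluorobenzyl on a sulfur. The bearing steps are those varying the group on the sulfur: the move from propyl to the aryl-bearing group, a 10-fold lower number from compound 2 to compound 3 (1.02 log units; beyond the scatter), was large, so removing the whole 4-fluorobenzyl group and leaving only iodo is expected to reverse it. Compound 4 is therefore expected to show a 13-fold higher number from compound 3 to compound 4 (1.12 log units; beyond the scatter). Compound 4 is estimated at 15000 nM, range 3000 nM to 60000 nM.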

Compound 4, half-maximal inhibitory concentration: 81300 nM
Compound 4: the middle estimate sits 5.4-fold (0.73 log units) below what was measured, outside the stated range (above it).
By their numbers in this assay, from the lowest: compound 3; then compound 1; then compound 2; then compound 4.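

Iodo on the sulfur gives the highest number of the four, with a 71-fold higher number from compound 3 to compound 4 (1.85 log units; beyond the scatter), a 28-fold higher number from compound 1 to compound 4 (1.45 log units; beyond the scatter) and a 6.8-fold higher number from compound 2 to compound 4 (0.83 log units; beyond the scatter). Both benzyl groups and the butyl chain therefore stand below iodo, so carbon attached to the sulfur is favoured over iodo in this set, with or without an aryl ring. On these data alone, whether an unsubstituted benzyl, a longer chain ending in phenyl, or an amine at the end of a butyl chain would match compound 3 stays open. Nothing available explains the size of these steps.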